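Vanillin-Derived Imine in a Selenazole-Thiadiazole Series

A few compounds are considered here, and "the series" means these few. Any claim that something is new, unique, unknown or untested is made for them only; others in the source may bear on it.

Compound 1, `Fc1ccc(/C=N/c2nnc(SCc3c[se]c(-c4ccccc4)n3)s2)cc1`: 56900 nM
Compound 2, `Oc1ccccc1/C=N/c1nnc(SCc2c[se]c(-c3ccccc3)n2)s1`: 38700 nM

In a functional assay on L1210 cells (Mus musculus) for antiproliferative activity, read by CCK-8 assay (on this read-out lower numbers stand for stronger inhibition and higher numbers for weaker inhibition), compound 2 gives 38700 nM, the lowest of the two numbers, while compound 1 gives 56900 nM. Among the measured compounds shown here, the only measured step, a 1.5-fold lower number from compound 1 to compound 2 (0.17 log units; within the scatter), also changes the aryl group on the imine carbon and stays within the scatter. Compound 3, `COc1cc(/C=N/c2nnc(SCc3c[se]c(-c4ccccc4)n3)s2)ccc1O`, differs from compound 2 by 4-hydroxy-3-methoxyphenyl in place of 2-hydroxyphenyl on a carbon with a double bond to nitrogen. For the measured compounds named here, no measured step covers this change, and the one related step is flat, so no shift beyond the scatter is expected. Compound 3 is therefore estimated at 36000 nM, between 12000 nM and 100000 nM, a step of a 1.1-fold lower number from compound 2 to compound 3 (0.03 log units; within the scatter).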

Compound 3, half-maximal inhibitory concentration: > 100000 nM
Compound 3: a limit, no number (the forecaster's own chance of this, stated with the estimate: 10%); at least 2.7-fold (0.44 log units) between middle value and limit.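

On a carbon with a double bond to nitrogen, 4-hydroxy-3-methoxyphenyl in place of 2-hydroxyphenyl gives an at least 2.5-fold higher number from compound 2 to compound 3 (0.41 log units; beyond the scatter) in this assay, so the aryl group at this position can move the read-out beyond the scatter. Against 4-fluorophenyl the same group gives an at least 1.7-fold higher number from compound 1 to compound 3 (0.24 log units; that floor lies within the scatter), a comparison that fixes no order. The reading for compound 3 is a limit of the assay, not a number: the limit of > 100000 nM in this assay, at which 1 of the 3 values shown sits.

Still open, from the compounds shown here alone, is which part of the change carries the step, the methoxy or the shifted hydroxy, and how far past the limit compound 3 lies. Also open, going by these compounds, is how an amine or a carboxylic acid in place of that hydroxy would read.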